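This account rests on a few compounds, and the source may have more. Where it says the series, first, only, none or still open, it means among the compounds named here.

Two compounds of the series carry a measured number. Compound 1 `CCCCC/C=C/C/C=C/CCCCCCCC(=O)NC(C(=O)OCC)c1nnn[nH]1` gives 11300 nM in a functional assay on HT-22 cells (Mus musculus), read by MTT assay, with stated times of 2 h, 20 h and 4 h; a higher number here means that more compound is needed for the effect, a lower number that less compound is needed. Compound 2 `CCCCC/C=C/C/C=C/CCCCCCCC(=O)NCCCCCC(=O)OCC(O)C1OC(=O)C(OCc2ccccc2)=C1OCc1ccccc1` gives in this assay the lower of the two numbers at 8200 nM; its nearest neighbour is compound 1, and the gap between the two lies within the scatter, so no order between them can be read from these data. Within the data shown here, no pair measured so far differs in one place only, so no single step has yet been measured.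

Compound 3 `CCCCCCCCCCCCCCCCCC(=O)NCCCCCC(=O)OCC(O)C1OC(=O)C(OCc2ccccc2)=C1OCc1ccccc1` has not been measured. It differs from compound 2 in one place: decyl in place of deca-1,4-dien-1-yl on a saturated chain carbon, seven bonds along the chain from a carbonyl carbon. The rest of compound 2 is kept unchanged. Among the measured compounds shown here, both measured numbers sit close together, and nothing measured so far shows what the change from deca-1,4-dien-1-yl to decyl does. The step of a 1.2-fold higher number from compound 2 to compound 3 (0.09 log units; within the scatter) is expected to be a change in this assay of no more than the scatter, in either direction. Compound 3 is expected to give about 10000 nM in this assay, with a range from 4000 nM to 25000 nM.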

Compound 3, half-maximal effective concentration: 2500 nM
Compound 3: middle estimate off by 4.0-fold (0.60 log units), on the high side; measured number outside the range, below it.
By their numbers in this assay, from the lowest: compound 3; then compounds 2 and 1 (each within the scatter of the next).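

In this assay, decyl in place of deca-1,4-dien-1-yl on a saturated chain carbon, seven bonds along the chain from a carbonyl carbon, gives a 3.3-fold lower number from compound 2 to compound 3 (0.52 log units; beyond the scatter), the first single step read in this series. The assay therefore responds to a change at this position, even though the group that leaves and the group that enters both hold 10 carbon atoms and neither has a ring; in the computed comparison, the difference lies in the 2 double bonds of the leaving group. No information is available on what underlies this step.

From the compounds shown here alone, with a single step at this position, it remains open whether the saturated chain itself matters or whether removing either double bond alone would give a similar step, and how a longer saturated chain, a shorter saturated chain or a chain ending in a carboxylic acid would compare with decyl. Going by these compounds, it is also open whether the same change keeps its direction and size on the core of compound 1, whose tetrazole-bearing end differs from that of compound 2 and compound 3.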